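Adding a Second Chloro to Compound 1

A few compounds are considered here, and "the series" means these few. Any claim that something is new, unique, unknown or untested is made for them only; others in the source may bear on it.

compound 1 `O=C1/C(=C\c2ccccc2Cl)c2ccccc2N1c1c(Cl)cccc1Cl`: > 100 ug/mL
compound 2 `O=C1/C(=C\c2cc3ccccc3nc2Cl)c2ccccc2N1c1c(Cl)cccc1Cl`: "not determined" (no result reported)
compound 3 `Cc1ccc2nc(Cl)c(/C=C3\C(=O)N(c4c(Cl)cccc4Cl)c4ccccc43)cc2c1C`: < 1 ug/mL

These three compounds share one core and were tested in a functional assay on HuTu80 cells (Homo sapiens) for cytotoxicity, read by MTT assay, with a stated time of 72 h; on this read-out lower numbers stand for an effect already at smaller amounts and higher numbers for an effect only at larger amounts of compound. For compound 1 the entry > 100 ug/mL is a limit of the assay, not a measured number; this is the limit of > 100 ug/mL in this assay, at which 1 of the 3 values shown sits. Compound 2 has no result in this assay. For compound 3 the entry < 1 ug/mL is again a limit, namely (the limit of < 1 ug/mL in this assay, at which 1 of the 3 values shown sits). Within the data shown here, compound 1 therefore stands at the weak end of what was recorded, without a number of its own, and no step between two measured compounds is available to lean on.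

Compound 4 `O=C1/C(=C\c2c(Cl)cccc2Cl)c2ccccc2N1c1c(Cl)cccc1Cl` differs from compound 1 in one place: chloro in place of hydrogen on an aromatic carbon. Among the measured compounds shown here, no measured pair shows what such a change does here, so any expectation is loose. Compound 4 is expected to give about 60 ug/mL in this assay, within a range from 15 ug/mL to 200 ug/mL. The expected step of an at least 1.6-fold lower number from compound 1 to compound 4 (0.22 log units; that floor lies within the scatter) is a modest move toward smaller amounts, with a real chance that only a limit is reported again.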

Compound 4, concentration for half-maximal effect: 100 ug/mL
The estimate for compound 4 lay 1.7-fold (0.22 log units) below the measured number; measured number inside the range.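

In this assay, chloro in place of hydrogen, which turns 2-chlorophenyl into 2,6-dichlorophenyl, gives a number no higher from compound 1 to compound 4 (the limit leaves the size open). Among these compounds, this is the first look at a change at this place on the ring: the second chloro does not raise the number, and compound 4 gives a true reading of 100 ug/mL. The size of the step cannot be read, because the entry for compound 1 is a limit of the assay and not a number: the limit of > 100 ug/mL in this assay, at which 1 of the 4 values shown sits.

Going by these compounds, whether a methoxy group or an amine at the same place would give a lower number stays open. Among the compounds shown here, also open is whether chloro at this place would act alike on other compounds with the shared core, as only this one pair shows the change.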